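Chloro in place of trifluoromethyl, second instance in series

A few compounds are considered here, and "the series" means these few. Any claim that something is new, unique, unknown or untested is made for them only; others in the source may bear on it.

Of the compounds shown here, three on the shared core have been measured. Compound 1 `O=C(Nc1cccc(C(F)(F)F)c1)c1nccc2ccccc12` carries a trifluoromethyl on the anilide ring. In a functional assay on NUGC-3 cells (Homo sapiens) for inhibition, read by sulforhodamine B assay, with a stated time of 48 h (on this read-out higher numbers stand for weaker inhibition of growth and lower numbers for stronger inhibition of growth), compound 1 gives only a limit, > 10000 nM. Compound 2 `O=C(Nc1ccccc1C(F)(F)F)c1nccc2ccccc12` has the same atoms as compound 1, joined differently; the difference between the two cores is not broken down here. In this assay compound 2 likewise gives only a limit, > 10000 nM. Compound 3 `O=C(Nc1ccccc1Cl)c1nccc2ccccc12` is reached from compound 2 by chloro in place of trifluoromethyl on an aromatic carbon. In this assay compound 3 also returns only a limit, > 10000 nM. The step that the two limits leave unreadable from compound 2 to compound 3 therefore cannot be sized, because both ends sit at the limit of > 10000 nM in this assay, at which 3 of the 3 values shown sit.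

Compound 4 `O=C(Nc1cccc(Cl)c1)c1nccc2ccccc12` is not yet measured. It is reached from compound 1 by chloro in place of trifluoromethyl on an aromatic carbon. This is the same kind of change as that from compound 2 to compound 3, but the surroundings differ: in compound 3 the chloro sits ortho to a large group, in compound 4 it sits meta to a large group.

Among the measured compounds shown here, nothing among the measured compounds shows a readable step for this change, and all three values rest at the limit. The step from compound 1 to compound 4 in this assay is therefore expected to be small, a step that the limit leaves unreadable from compound 1 to compound 4, resting on compound 1 at > 10000 nM and on compound 3 at > 10000 nM. Compound 4 is expected to give about 15000 nM, with a plausible range from 4000 nM to 60000 nM, and most likely only a limit again.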

Compound 4, concentration for 50% growth inhibition: > 10000 nM
Compound 4: only a limit was reported (the forecaster's own chance of this, stated with the estimate: 80%); the middle value is on the limit's open side.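

No new step can be read: compound 4 gives only a limit, so neither the change from compound 1 to compound 4 nor that from compound 2 to compound 3 can be sized in this assay: the limit of > 10000 nM in this assay, at which 4 of the 4 values shown sit.

The compounds shown leave open whether chloro or trifluoromethyl on the anilide ring of the shared core has any readable effect on growth inhibition in this assay, and how these four compounds rank against one another.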